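From cyclopentyl to cyclohexyl on a shared core

A few compounds are considered here, and "the series" means these few. Any claim that something is new, unique, unknown or untested is made for them only; others in the source may bear on it.

In a functional assay on MCF7 cells (Homo sapiens) for cytotoxicity, read by WST assay, with a stated time of 72 h (a lower number here means a stronger inhibitor, a higher number a weaker inhibitor), the measured compounds read as follows:
Compound 1 `Cc1ccc(C2(c3ccc(O)cc3)C(=O)Nc3c2ccc(F)c3F)cc1` gives 1.7 nM
Compound 2 `COc1ccc2c(c1C)NC(=O)C2(c1ccc(O)cc1)c1ccc(F)cc1` gives 6.3 nM
Compound 3 `COc1ccc2c(c1C)NC(=O)C2(c1ccc(O)cc1)C1CCCC1` gives 1 nM

Compound 3 and compound 1 lie within the usual scatter of each other, and both numbers are lower than that of compound 2. Compound 4 `COc1ccc2c(c1C)NC(=O)C2(c1ccc(O)cc1)C1CCCCC1` carries cyclohexyl in place of cyclopentyl on a saturated ring carbon. Among the compounds with values here, the one measured step at this place is modest (a 6.3-fold lower number from compound 2 to compound 3 (0.80 log units; beyond the scatter)) and swaps 4-fluorophenyl for cyclopentyl. Within the data shown here, no measured compound compares cyclopentyl with cyclohexyl directly. Both are non-aromatic rings of carbon only, so a smaller change is expected here. The expected move stays within the scatter (a 1.4-fold higher number from compound 3 to compound 4 (0.15 log units; within the scatter)). Compound 4 is estimated at 1.4 nM (range 0.4 nM to 4.5 nM).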

Compound 4, half-maximal inhibitory concentration: 14 nM
For compound 4 the middle estimate is 10-fold (1.00 log units) below the measured one; the measured number lies above the stated range.
By their numbers in this assay, from the lowest: compounds 3 and 1 (each within the scatter of the next); then compound 2; then compound 4.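

At this place, the size of a non-aromatic carbon ring matters in this assay: cyclohexyl in place of cyclopentyl gives a 14-fold higher number from compound 3 to compound 4 (1.15 log units; beyond the scatter) in this series. Cyclohexyl in place of 4-fluorophenyl gives a 2.2-fold higher number from compound 2 to compound 4 (0.35 log units; beyond the scatter) and so moves the number the opposite way from cyclopentyl, showing that swapping this aromatic ring for a non-aromatic one can either lower or raise the number. No evidence here explains the size of this step. Going by these compounds, how cyclobutyl or a tetrahydropyran ring, which carries an oxygen in the ring, would read at this place remains open. So does whether the same ring change would act alike on the core of compound 1.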